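Sulfonamide aryl variation: removing the dichloro substitution

The compounds below may be only part of what the source reports. "The series", "measured", "known", "first", "only" and "open" are said of these compounds alone.

Measured compounds:
compound 1, `Cc1ccc(S(=O)(=O)Nc2nc(-c3cccc([N+](=O)[O-])c3)cs2)cc1`, 48 nM
compound 2, `O=[N+]([O-])c1cccc(-c2csc(NS(=O)(=O)c3ccc(Cl)c(Cl)c3)n2)c1`, 120 nM
compound 3, `COc1ccc(S(=O)(=O)Nc2nc(-c3cc(C(F)(F)F)ccc3F)cs2)cc1OC`, 39 nM

In an assay on isolated protein for inhibition of kynurenine 3-monooxygenase (Rattus norvegicus) (on this read-out higher numbers stand for weaker inhibition and lower numbers for stronger inhibition), compound 2 has the highest number of the three. The nearest is compound 1, which gives 48 nM; the furthest is compound 3, which gives 39 nM. Both gaps are beyond the scatter, so compound 2 is the weakest inhibitor of the three on this read-out.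

Compound 4, `O=[N+]([O-])c1cccc(-c2csc(NS(=O)(=O)c3ccccc3)n2)c1`, is not yet measured. It differs from compound 2 in one place: phenyl in place of 3,4-dichlorophenyl on a sulfonyl sulfur. Within the data shown here, the single measured step that bears on this position is the one from compound 1 to compound 2, a 2.5-fold higher number from compound 1 to compound 2 (0.40 log units; beyond the scatter), where the 4-methylphenyl became the 3,4-dichlorophenyl. Compound 3 carries a different aryl on both the sulfonyl sulfur and the core, so it offers no one-place comparison.

Taking the two chlorines off the sulfonyl aryl reverses part of that step, so the expectation for compound 4 in this assay is a modest lower number, roughly back to where compound 1 stands: a 2.0-fold lower number from compound 2 to compound 4 (0.30 log units; within the scatter). The estimate for compound 4 is 60 nM, with a range from 25 nM to 150 nM.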

Compound 4, half-maximal inhibitory concentration: 200 nM
Compound 4: middle estimate off by 3.3-fold (0.52 log units), on the low side; the whole stated range lies below it.
By their numbers in this assay, from the lowest: compounds 3 and 1 (each within the scatter of the next); then compounds 2 and 4 (each within the scatter of the next).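

Taking both chlorines off the sulfonyl aryl gives a 1.7-fold higher number from compound 2 to compound 4 (0.22 log units; within the scatter), so the 3,4-dichlorophenyl and the plain phenyl on the sulfonyl sulfur cannot be told apart, and the pair of chlorines has no readable effect on the core of compound 2. The comparison that now carries weight is the methyl alone: hydrogen in place of methyl on an aromatic carbon gives a 4.2-fold higher number from compound 1 to compound 4 (0.62 log units; beyond the scatter), which isolates that single group on an otherwise unchanged structure. Compound 1 therefore separates from both compound 2 and compound 4, so the earlier step is better read as an advantage tied to the 4-methylphenyl than as a penalty tied to the chlorines, and of the three sulfonyl aryl groups on this core only the 4-methylphenyl stands apart.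

As far as these compounds go, whether that advantage belongs to the methyl itself or would also appear with an ethyl, a methoxy or a single chlorine on the phenyl remains open, as does whether it would carry over to a core bearing the aryl of compound 3. Nothing among the data shown gives a reason for the methyl step.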